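The source may hold more compounds than are shown below. What is called first, only, known or untested is meant among the compounds shown, and "the series" means these compounds.

In an assay on U2OS cells for activation of nuclear factor erythroid 2-related factor 2 (Homo sapiens), read by beta-arrestin recruitment, with a stated time of 6 h (on this read-out lower numbers stand for an effect already at smaller amounts and higher numbers for an effect only at larger amounts of compound), compound 1 `O=S(=O)(/C=C\c1ncccc1F)c1ccccc1F` gives 482 nM and compound 2 `O=S(=O)(/C=C\c1ncccc1Cl)c1ccccc1F` gives 1030 nM. The change from compound 1 to compound 2 is chloro in place of fluoro on an aromatic carbon, and it made a 2.1-fold higher number from compound 1 to compound 2 (0.33 log units; beyond the scatter). Compound 3 `O=S(=O)(/C=C/c1ccc(Cl)nc1)c1ccc(F)cc1` reaches only a limit of this assay, namely > 10000 nM. How the core of compound 3 differs from that of compound 1 is not broken down here. Compound 4 `O=S(=O)(/C=C/c1ccc(Cl)nc1)c1ccc(Cl)cc1` is not yet measured; it differs from compound 3 by chloro in place of fluoro on an aromatic carbon. This is the same kind of change as from compound 1 to compound 2, but the place differs: there the chloro sits on a six-membered aromatic ring with 1 nitrogen, ortho to a large group and two atoms from the ring nitrogen; here it sits on a ring of carbon only, para to a large group. Because compound 3 already sits at the limit of > 10000 nM in this assay, at which 1 of the 3 values shown sits, and the earlier step of a 2.1-fold higher number from compound 1 to compound 2 (0.33 log units; beyond the scatter) was modest, compound 4 is expected to show a step that the limit leaves unreadable from compound 3 to compound 4, most likely again only a limit. The estimate for compound 4 is 20000 nM.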

Compound 4, half-maximal effective concentration: > 10000 nM
Compound 4 gave a limit, no number; the forecaster's own chance of this, stated with the estimate: 80%; the middle value lies beyond the limit too.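

In this assay, among these compounds, no step from compound 3 to compound 4 can be read, because both stand at a limit and not at a number: the limit of > 10000 nM in this assay, at which 2 of the 4 values shown sit.

The compounds shown leave open whether chloro in place of fluoro on this ring of carbon only changes the read-out at all.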